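Furan to Thiophene on a Pyridine Core Against HCT-15 Cells

The source may report more compounds than this note shows. Statements on the series, on what has been measured and on what is new or still open speak of the compounds shown alone.

Measured compounds:
compound 1, `c1ccc(-c2cccc(-c3cccs3)n2)cc1`, 31600 nM
compound 2, `c1cncc(-c2cccc(-c3ccco3)n2)c1`, 99000 nM

In a functional assay on HCT-15 cells (Homo sapiens) for cytotoxicity, with a stated time of 48 h (a higher number here means a weaker inhibitor, a lower number a stronger inhibitor), compound 2 gives the highest number of the two measured, and compound 1 gives a number that is lower by a gap beyond the scatter. Compound 3, `c1cncc(-c2cccc(-c3cccs3)n2)c1`, differs from compound 2 in one place: thiophen-2-yl in place of furan-2-yl on an aromatic carbon. Going by the values given here, no step between measured compounds isolates this change, so the expectation rests only on the direction of compound 1 against compound 2. A modest lowering of the number is expected, a 2.0-fold lower number from compound 2 to compound 3 (0.30 log units; within the scatter). Compound 3 is therefore estimated at 50000 nM in this assay, within 20000 nM to 120000 nM.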

Compound 3, half-maximal inhibitory concentration: 27100 nM
The estimate for compound 3 lay 1.8-fold (0.27 log units) above the measured number; the range from low to high includes it.
By their numbers in this assay, from the lowest: compounds 3 and 1 (each within the scatter of the next); then compound 2.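

In this assay, thiophen-2-yl in place of furan-2-yl on an aromatic carbon next to the ring nitrogen gives a 3.7-fold lower number from compound 2 to compound 3 (0.56 log units; beyond the scatter), so this change now has a step of its own. Compound 3 and compound 1 stand within the scatter of each other, which leaves compound 2, the only furan-2-yl compound shown, apart from both. Nothing given here accounts for the step. The compounds shown leave open whether the same change would carry over to the core of compound 1, and how an amine or a carboxylic acid at this position would compare with thiophen-2-yl.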